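The source may report more compounds than this note shows. Statements on the series, on what has been measured and on what is new or still open speak of the compounds shown alone.

Working notes on the series.

The shared core of compound 1 `CCOC(=O)C1=C(Nc2ccccc2)S/C(=C\c2ccc(C(=O)O)cc2)C1=O` carries a 4-carboxyphenyl on the double-bonded chain carbon; compound 2 `CCOC(=O)C1=C(Nc2ccccc2Br)S/C(=C\c2ccc[nH]2)C1=O` carries a different group there and a bromine-bearing aniline instead. In a functional assay on K562 cells (Homo sapiens) for inhibition, read by MTT assay, with a stated time of 72 h, tested at 10 uM (a lower number here means less inhibition, a higher number more inhibition at the concentration tested (going by the name of the read-out)), compound 1 gives 27.5%. In this assay compound 2 gives 20.5%. The gap between the two numbers is within the scatter, so compound 1 and compound 2 cannot be told apart on these data; both sit in the low range of the read-out. Going by the values given here, no pair of measured compounds differs in a single place, so no measured step is available to judge the size of a change at the double-bonded chain carbon.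

Compound 3 `CCOC(=O)C1=C(Nc2ccccc2)S/C(=C\c2cc3ccncc3[nH]2)C1=O` differs from compound 1 in one place: a group of 9 heavy atoms (7 carbon, 2 nitrogen; one five-membered aromatic ring with 1 hetero atom, one six-membered aromatic ring with 1 hetero atom) in place of a group of 9 heavy atoms (7 carbon, 2 oxygen; one six-membered aromatic ring of carbon only), on a double-bonded chain carbon bound to a double-bonded ring carbon. Among the compounds with values here, with no measured step to rest on, the expectation for this assay is a step from compound 1 to compound 3 of a number 2.5 percentage points higher from compound 1 to compound 3 (within the scatter), that is, no change beyond the scatter in either direction. Compound 3 is therefore estimated at 30% in this assay, with a range from 10% to 55%.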

Compound 3, a percentage reported as inhibition, at one concentration (the size of the read-out at that concentration, not a potency): 22.8%
Compound 3: middle estimate off by 7.2 percentage points, on the high side, within the range that was stated.
By their numbers in this assay, from the lowest: compounds 2, 3 and 1 (each within the scatter of the next).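

In this assay, going by these compounds alone, the first single-place step at this position is a number 4.7 percentage points lower from compound 1 to compound 3 (within the scatter), so 4-carboxyphenyl and the group with one five-membered and one six-membered aromatic ring, each with 1 hetero atom, cannot be told apart on the double-bonded chain carbon. The two groups match in heavy-atom count and in hydrogen-bond donors and acceptors, yet differ in ring make-up and in carrying oxygen or nitrogen, and this difference in make-up produces no step beyond the scatter in this comparison. No measured property of these compounds bears on this result, and so the data offer no explanation for it.

The compounds shown leave open whether any group on the double-bonded chain carbon, such as a dimethylamino group or a longer alkyl chain in place of 4-carboxyphenyl, would move the read-out beyond the scatter. Within the data shown here, they also leave open what the bromine on the aniline contributes, since compound 2 differs from compound 1 and from compound 3 in more than one place and no single-place step isolates that atom.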